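Swapping 3-hydroxyazetidin-1-yl for 3-hydroxypyrrolidin-1-yl at a limit

The source may report more compounds than this note shows. Statements on the series, on what has been measured and on what is new or still open speak of the compounds shown alone.

Compound 1 `Nc1ncc(-c2ccc(C(=O)N3CC(O)C3)cc2)nc1-c1ccc(C(F)(F)F)cc1` stands in an ADME assay on microsomes from liver (Rattus norvegicus) for metabolic stability, read by LC-MS, using NADPH, with a stated time of 30 min, tested at 0.1 uM, in the presence of a further agent that is not named here (a lower number here means that less of the compound is left, a higher number that more of the compound is left), at > 90% as its reading, which is a limit and not a number. Compound 2 `Nc1ncc(-c2ccc(C(=O)N3CCC(O)C3)cc2)nc1-c1ccc(C(F)(F)F)cc1` reads > 90% as a limit too. Compound 3 `Nc1ccc(-c2nc(-c3ccc(S(=O)(=O)C4CC4)cc3)cnc2N)cn1` reads > 90% as a limit too. Compound 1 thus shares the limit of > 90% in this assay, at which 3 of the 3 values shown sit, and offers no exact starting number. Compound 4 `Nc1ncc(-c2ccc(C(=O)N3CC[C@H](O)C3)cc2)nc1-c1ccc(C(F)(F)F)cc1` differs from compound 1 by 3-hydroxypyrrolidin-1-yl in place of 3-hydroxyazetidin-1-yl on a carbonyl carbon on a carbonyl carbon, with 3-hydroxypyrrolidin-1-yl in place of 3-hydroxyazetidin-1-yl. Going by the values given here, the one measured step with this change is a step that the two limits leave unreadable from compound 1 to compound 2 and it gives no size to carry over. The expected step that the limit leaves unreadable from compound 1 to compound 4 stays within the usual scatter, in no set direction. In this assay the estimate for compound 4 is 93% with an expected range from 85% to 100% as its likely spread.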

Compound 4, percent of the compound remaining: > 90%
Compound 4 gave a limit, no number; the forecaster's own chance of this, stated with the estimate: 85%; the middle value is on the limit's open side.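

Compound 1, compound 2 and compound 4 yield no readable step, since each gives a limit and not a number: the limit of > 90% in this assay, at which 4 of the 4 values shown sit. Going by these compounds, whether the change of ring or the configuration drawn in compound 4 alters the reading in this assay stays open.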